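This account rests on a few compounds, and the source may have more. Where it says the series, first, only, none or still open, it means among the compounds named here.

Measured so far:
compound 1 `CCCCCCCCCO[C@@H]1[C@@H](N)[C@@H](OCC(O)CNCCN)O[C@H](CN)[C@H]1OCCCCCCCCC` gives 53% in a toxicity assay on the whole organism (J774 cells) for cytotoxicity, with Mus musculus as the target, read by MTT assay, with a stated time of 24 h, tested at 30 uM; a higher number here means a weaker effect of the compound at the concentration tested, a lower number a stronger effect;
compound 2 `CCCCCCCCCO[C@@H]1[C@@H](N)[C@@H](OC[C@@H](O)CN)O[C@H](CN)[C@H]1OCCCCCCCCC` gives 7.2% in this assay.

Compound 2 stands lowest of the two numbers, with compound 1 its nearest neighbour; the step of a number 45.8 percentage points lower from compound 1 to compound 2 (beyond the scatter) exchanged one chain for another. Compound 3 `CCCCCCCCCO[C@@H]1[C@@H](N)[C@@H](OC[C@H](O)CN)O[C@H](CN)[C@H]1OCCCCCCCCC` differs from compound 2 only in configuration: the two compounds have the same atoms and bonds and differ only in configuration as drawn: 1 of 6 stereo elements differ; a stereocentre at a saturated chain carbon is drawn S in compound 2 and R in compound 3. Among the measured compounds shown here, no measured step concerns a change of configuration alone, so the step from compound 1 to compound 2 does not bear on this one. Without any comparable pair, no step beyond the scatter is expected, and compound 3 is estimated at 10% (0% to 35%), an expected step of a number 2.8 percentage points higher from compound 2 to compound 3 (within the scatter).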

Compound 3, a percentage reported as activity, at one concentration (the size of the read-out at that concentration, not a potency): 14.4%
For compound 3 the middle estimate is 4.4 percentage points below the measured one; low and high end bracket the measured number.
By their numbers in this assay, from the lowest: compounds 2 and 3 (each within the scatter of the next); then compound 1.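

In this assay, among the compounds shown here, the stereocentre at a saturated chain carbon is the first change of configuration alone, and the step is a number 7.2 percentage points higher from compound 2 to compound 3 (within the scatter). The exchange of chains gives a large step with either drawn configuration, a number 38.6 percentage points lower from compound 1 to compound 3 (beyond the scatter), so in these compounds the chain matters far more than this stereocentre. The comparison isolates that single stereocentre: the fact that compounds 2 and 3 differ only in the configuration as drawn

Still open, on these data alone, is whether a longer chain ending in a primary amine, or a carboxylic acid in place of that amine, would stand with compound 1 or with compound 3 in this assay.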